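Dropping One Chloro Group from a Boron-Containing Enone

A few compounds are considered here, and "the series" means these few. Any claim that something is new, unique, unknown or untested is made for them only; others in the source may bear on it.

Compound 1 `O=C(/C=C/c1ccc2c(c1)B(O)OC2)c1ccc(Cl)c(Cl)c1` carries two chloro groups on one of its aromatic rings, joined through a carbonyl-bearing chain to a shared core that holds a boron atom. In an ADME assay on L929 cells (Mus musculus) for cytotoxicity, read by resazurin assay, with a stated time of 72 h (on this read-out higher numbers stand for weaker inhibition and lower numbers for stronger inhibition), compound 1 reaches only a limit, giving > 10 ug/mL, so its position is known just as a bound and not as a number. Compound 2 `COCOc1ccccc1C(=O)/C=C/c1ccc2c(c1)B(O)OC2` shares the same core with a different aromatic ring attached, and in this assay compound 2 gives 9.02 ug/mL. Of the two values shown, one sits at the limit of > 10 ug/mL in this assay, at which 1 of the 2 values shown sits.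

Compound 3 `O=C(/C=C/c1ccc2c(c1)B(O)OC2)c1ccc(Cl)cc1` is the next compound to be tested. It differs from compound 1 in one place: hydrogen in place of chloro on an aromatic carbon. Among the measured compounds shown here, no two measured compounds differ by only one change, so no measured step exists to lean on. The expectation for this change rests on the bound seen for compound 1 alone.

From compound 1 the step that the limit leaves unreadable from compound 1 to compound 3 in this assay is expected to be none beyond the usual scatter. For compound 3 the estimated value in this assay is 12 ug/mL, within a range from 5 ug/mL to 30 ug/mL.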

Compound 3, half-maximal inhibitory concentration: > 10 ug/mL
Compound 3: only a limit was reported; the forecaster's own chance of this, stated with the estimate: 60%; the middle value lies beyond the limit too.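

No new step can be read from compound 1 to compound 3, because in this assay each of the two compounds gives only a limit and not a number: the limit of > 10 ug/mL in this assay, at which 2 of the 3 values shown sit.

The compounds shown leave open whether hydrogen in place of chloro on an aromatic carbon changes the cytotoxicity at all, and if so, by how much.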